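The source may report more compounds than this note shows. Statements on the series, on what has been measured and on what is new or still open speak of the compounds shown alone.

Series values in an ADME assay on WI-38 cells (Homo sapiens) for cytotoxicity, read by MTT assay, with a stated time of 72 h; a lower number here means a stronger inhibitor, a higher number a weaker inhibitor:
- compound 1 `O=C(CCc1cccc2c1B(O)OC2)Nc1cccc(-c2ccc(Cl)cc2)c1`: 9800 nM
- compound 2 `COc1ccc(-c2cccc(NC(=O)CCc3cccc4c3B(O)OC4)c2)cc1`: 1400 nM

Within the data shown here, of these two numbers, compound 2 at 1400 nM holds the lower, and compound 1 at 9800 nM is its only neighbour. The next compound to read is compound 3 `COc1cc(OC)cc(-c2cccc(NC(=O)CCc3cccc4c3B(O)OC4)c2)c1`, which carries 3,5-dimethoxyphenyl in place of 4-methoxyphenyl on an aromatic carbon.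

Among the measured compounds shown here, only one measured step bears on this change: a 7.0-fold lower number from compound 1 to compound 2 (0.85 log units; beyond the scatter). It is modest, and it replaces chloro with methoxy on an aromatic carbon. It therefore gives a size for a change of this kind, but no direct reading on the 3,5-dimethoxyphenyl group. With a single step and two values, the series shows no trend that could be carried forward, so no step beyond the scatter is expected in this assay, and no direction can be firmly assigned. The expected step is a 1.3-fold higher number from compound 2 to compound 3 (0.11 log units; within the scatter), and the uncertainty stays wide, as the measured step shows that a single change can move the number beyond the scatter. For compound 3 the estimated value is 1800 nM, with an expected range of 500 nM to 7000 nM.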

Compound 3, half-maximal inhibitory concentration: 1700 nM
Compound 3: the middle estimate sits 1.1-fold (0.02 log units) above what was measured; low and high end bracket the measured number.
By their numbers in this assay, from the lowest: compounds 2 and 3 (each within the scatter of the next); then compound 1.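

In this assay the change from 4-methoxyphenyl to 3,5-dimethoxyphenyl gives a 1.2-fold higher number from compound 2 to compound 3 (0.08 log units; within the scatter) so this aromatic position takes the larger group, with its added methoxy, without a step beyond the scatter. Measured against 4-chlorophenyl, the same group gives a 5.8-fold lower number from compound 1 to compound 3 (0.76 log units; beyond the scatter) so the gap first seen with a single methoxy group now appears with a second methoxy-bearing compound; among these three compounds, the two carrying methoxy lie within the scatter of each other and the one carrying chloro stands apart, with none going against this grouping. No supporting measurement is available to account for these numbers.

The compounds shown leave open how an unsubstituted phenyl, a hydroxyl, an amine or a carboxylic acid on this ring would read, and so whether the separation from compound 1 is specific to methoxy. Also open, on these data alone, is how a longer chain linking the amide carbonyl to the shared core would read in this assay and whether the grouping seen here would persist with that change.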